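The source may report more compounds than this note shows. Statements on the series, on what has been measured and on what is new or still open speak of the compounds shown alone.

Measured so far in a functional assay on MGC-803 cells (Homo sapiens) for cytotoxicity, read by MTT assay, with a stated time of 48 h; a higher number here means a weaker inhibitor, a lower number a stronger inhibitor:

compound 1, `CC1=NN(S(=O)(=O)c2ccc(C)cc2)C(c2cc(Br)ccc2O)C1`, gives 30700 nM
compound 2, `CC(=O)Oc1ccccc1C1CC(C)=NN1C(=O)CN(C(C)C)C(C)C`, gives 20100 nM
compound 3, `O=C(CCl)N1N=C(c2cc3ccccc3oc2=O)CC1c1ccccc1`, gives 2020 nM

Among these three, compound 3 stands at the lowest number. Compound 2 sits higher by a gap beyond the usual scatter, and compound 1 higher still, also beyond the scatter, so compound 3 is the strongest inhibitor of the three in this assay.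

Compound 4, `CCN(CC)C1CCN(CC(=O)N2N=C(c3cc4ccccc4oc3=O)CC2c2ccccc2)CC1`, has not yet been measured. It keeps the core of compound 3 and differs from it in one place: 4-(diethylamino)piperidin-1-yl in place of chloro on a saturated chain carbon bound to a carbonyl carbon. Among the measured compounds shown here, no pair of measured compounds shows this kind of change, so no measured step can be leaned on.

Because compound 3 gives 2020 nM and the remaining two compounds share neither its core nor this change, the expectation for compound 4 rests on compound 3 alone. A step toward a higher number is expected, of a size near the edge of the scatter, so that the step of a 2.0-fold higher number from compound 3 to compound 4 (0.30 log units; within the scatter) is estimated as a modest weakening. Compound 4 is expected at 4000 nM, with a range from 1000 nM to 16000 nM.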

Compound 4, half-maximal inhibitory concentration: 32400 nM
The estimate for compound 4 lay 8.1-fold (0.91 log units) below the measured number; the measured number lies above the stated range.
By their numbers in this assay, from the lowest: compound 3; then compounds 2, 1 and 4 (each within the scatter of the next).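

In this assay, putting 4-(diethylamino)piperidin-1-yl in place of chloro on a saturated chain carbon bound to a carbonyl carbon gives a 16-fold higher number from compound 3 to compound 4 (1.21 log units; beyond the scatter) as a large weakening. Among the compounds shown here, this is the first step that can be read in this set, and it shows that the number at this place on the shared core responds strongly to what the chain carbon carries. The low number of compound 3 is not kept when chloro gives way to this much larger group. No measurement presented here accounts for the size of this step.

The compounds shown leave open whether the weakening follows from losing chloro, from gaining the piperidine ring or from the diethylamino group; a dimethylamino group or a morpholine ring on the same carbon would help to separate these. They also leave open whether the same exchange acts alike on another core.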